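The compounds below may be only part of what the source reports. "The series", "measured", "known", "first", "only" and "open" are said of these compounds alone.

Working notes on the series. In an assay on isolated protein for inhibition of protein deacetylase HDAC6 (Homo sapiens), read by fluorescence, with stated times of 3 h and 60 min (a lower number here means a stronger inhibitor, a higher number a weaker inhibitor), compound 2 `Nc1ccccc1NC(=O)c1ccc(CNC2=NC(=O)C(Cc3c[nH]c4ccccc34)N2)cc1` gives > 20000 nM, which is a limit of the assay and not a number. Compound 1 `Nc1ccccc1NC(=O)c1ccc(CNC2=NC(=O)C(c3ccccc3)N2)cc1` in this assay gives > 20000 nM, also a limit. Compound 3 `Nc1ccccc1NC(=O)c1ccc(CNC2=NC(=O)C(Cc3ccccc3)N2)cc1` in this assay gives > 20000 nM, again a limit. The steps between the three, a step that the two limits leave unreadable from compound 1 to compound 2, a step that the two limits leave unreadable from compound 1 to compound 3 and a step that the two limits leave unreadable from compound 2 to compound 3, cannot be sized, because of the limit of > 20000 nM in this assay, at which 3 of the 3 values shown sit. Compound 4 `CC(=O)N1C(NCc2ccc(C(=O)Nc3ccccc3N)cc2)=NC(=O)C1Cc1c[nH]c2ccccc12` is not yet measured; it differs from compound 2 by acetyl in place of hydrogen on an amine nitrogen in a ring. For the measured compounds named here, none of the measured steps has a readable size, so the change from compound 2 to compound 4 has no measured precedent; what the three measured compounds show is that every value so far sits at the limit. Compound 4 is therefore expected to stay near that limit, with the step that the limit leaves unreadable from compound 2 to compound 4 expected to be small, in no settled direction. For compound 4 in this assay the estimate is 30000 nM, in the range 10000 nM to 100000 nM.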

Compound 4, half-maximal inhibitory concentration: > 20000 nM
Compound 4: a limit, no number; the forecaster's own chance of this, stated with the estimate: 85%; the middle value lies beyond the limit too.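

The acetyl step from compound 2 to compound 4 cannot be read, because both compounds give a limit and not a number: the limit of > 20000 nM in this assay, at which 4 of the 4 values shown sit. The compounds shown leave open what size that step has and which change to the shared core, if any, would bring a value inside the limit in this assay.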